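Inverting the single stereocentre of compound 2

A few compounds are considered here, and "the series" means these few. Any claim that something is new, unique, unknown or untested is made for them only; others in the source may bear on it.

Compound 1 (`CCOC(=O)C(CCc1ccccc1)Nc1nc2ccccc2s1`): 520 nM
Compound 2 (`COC(=O)[C@H](CC1CCCCC1)Nc1nc2ccccc2o1`): 5 nM

In a functional assay for inhibition, with Homo sapiens as the target (a lower number here means a stronger inhibitor, a higher number a weaker inhibitor), compound 2 stands lowest of the two at 5 nM, a gap to compound 1 that lies beyond the scatter. Compound 3 (`COC(=O)[C@@H](CC1CCCCC1)Nc1nc2ccccc2o1`) is the next case: the two compounds have the same atoms and bonds and differ only in configuration as drawn: 1 of 1 stereo elements differ; a stereocentre at a saturated chain carbon is drawn S in compound 2 and R in compound 3. Among the compounds with values here, no measured pair shows what such a change does, so the expectation is tentative. The estimated step of a 10-fold higher number from compound 2 to compound 3 (1.00 log units; beyond the scatter) is upward, towards a weaker inhibitor and beyond the scatter. Compound 3 is estimated at 50 nM with an expected range from 7 nM to 400 nM in this assay.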

Compound 3, half-maximal inhibitory concentration: 100 nM
For compound 3 the middle estimate is 2.0-fold (0.30 log units) below the measured one; the range from low to high includes it.
By their numbers in this assay, from the lowest: compound 2; then compound 3; then compound 1.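

Drawing the stereocentre at the saturated chain carbon R instead of S gives a 20-fold higher number from compound 2 to compound 3 (1.30 log units; beyond the scatter) in this assay. This pair gives the series its first single-place comparison, and the S form is the stronger inhibitor of the two. The difference can be assigned to configuration alone, because nothing else varies: the fact that compounds 2 and 3 differ only in the configuration as drawn

As far as these compounds go, whether the preference for S persists with a carboxylic acid or an amide in place of the ester remains open. So does its persistence with a shorter chain in place of the cyclohexyl-bearing side chain.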